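Removing the benzyl group from compound 2

A few compounds are considered here, and "the series" means these few. Any claim that something is new, unique, unknown or untested is made for them only; others in the source may bear on it.

- Compound 1 (`COc1ccc2c(C(=O)/C(C#N)=C/c3c[nH]c4cc(F)ccc34)c[nH]c2c1`) in a functional assay on PC-3 cells (Homo sapiens) for cytotoxicity, read by WST assay, with a stated time of 24 h (a higher number here means a weaker inhibitor, a lower number a stronger inhibitor), gives 36000 nM as a measured value
- Compound 2 (`COc1ccc2c(C(=O)/C(C#N)=C/c3cn(Cc4ccc(Cl)cc4)c4ccccc34)c[nH]c2c1`) in this assay gives > 50000 nM as a limit
- Compound 3 (`COc1ccc2c(C(=O)/C(C#N)=C/c3c[nH]c4ccccc34)c[nH]c2c1`) awaits measurement

Compound 2 has no exact number, only the limit of the assay (> 50000 nM) as its result. Compound 3 differs from it by one change (hydrogen in place of 4-chlorobenzyl on an aromatic nitrogen), with hydrogen in place of 4-chlorobenzyl on an aromatic nitrogen. Going by the values given here, no measured pair shows this change. Compound 1 carries that same hydrogen and gives a measured value (36000 nM) in this assay, so a modest gain in strength is expected. The expected step (an at least 1.6-fold lower number from compound 2 to compound 3 (0.22 log units; that floor lies within the scatter)) is small. Compound 3 is estimated at (30000 nM), within an expected range from (12000 nM) to (50000 nM).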

Compound 3, half-maximal inhibitory concentration: > 50000 nM
Compound 3: only a limit was reported; the forecaster's own chance of this, stated with the estimate: 25%; at least 1.6-fold (0.22 log units) between middle value and limit.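

Replacing 4-chlorobenzyl with hydrogen on the aromatic nitrogen does not bring a readable value in this assay, so the step between compound 2 and compound 3 cannot be read. Hydrogen in place of fluoro on an aromatic carbon gives an at least 1.3-fold higher number from compound 1 to compound 3 (0.14 log units; that floor lies within the scatter), so a real effect of the fluoro is not established. Both comparisons run into the same ceiling: the limit of > 50000 nM in this assay, at which 2 of the 3 values shown sit.

From the compounds shown here alone, how far compound 2 and compound 3 lie beyond that limit stays open. So does whether an amine or a carboxylic acid on that aromatic nitrogen would give a measurable value.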